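Chain homologation in the dicarboxylate series, one carbon further

The source may hold more compounds than are shown below. What is called first, only, known or untested is meant among the compounds shown, and "the series" means these compounds.

Compound 3 `CC1OC(OC2CCCCC2OCCCCCCCC(C(=O)O)C(=O)O)C(O)C(O)C1O` gives in a functional assay on HL-60 cells (Homo sapiens) for inhibition (a higher number here means a weaker inhibitor, a lower number a stronger inhibitor), only a limit, > 5000000 nM. Compound 1 `CC1OC(OC2CCCCC2OCCCCCC(C(=O)O)C(=O)O)C(O)C(O)C1O` gives in this assay a limit, > 5000000 nM. Compound 2 `CC1OC(OC2CCCCC2OCCCCCCC(C(=O)O)C(=O)O)C(O)C(O)C1O` gives in this assay a limit, > 5000000 nM. For the measured compounds named here, the series so far shows (the limit of > 5000000 nM in this assay, at which 3 of the 3 values shown sit). The measured steps a step that the two limits leave unreadable from compound 1 to compound 2, a step that the two limits leave unreadable from compound 2 to compound 3 and a step that the two limits leave unreadable from compound 1 to compound 3 therefore cannot be sized. Compound 4 `CC1OC(OC2CCCCC2OCCCCCCCCC(C(=O)O)C(=O)O)C(O)C(O)C1O` differs from compound 3 by 2,2-dicarboxyethyl in place of dicarboxymethyl on a saturated chain carbon, seven bonds along the chain from an oxygen on a saturated carbon. Every earlier step of this kind in this assay sat at the limit, so no step beyond the scatter is expected, a step that the limit leaves unreadable from compound 3 to compound 4. Compound 4 is estimated in this assay at 10000000 nM, with a range from 5000000 nM to 50000000 nM, most probably reported again only as a limit.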

Compound 4, half-maximal inhibitory concentration: > 5000000 nM
Compound 4 was reported as a limit; the forecaster's own chance of this, stated with the estimate: 90%; the middle value does not contradict the limit.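

No step from compound 1, compound 2 or compound 3 to compound 4 can be read in this assay, since all four compounds sit at a limit: the limit of > 5000000 nM in this assay, at which 4 of the 4 values shown sit.
From the compounds shown here alone, whether these chain lengths differ at all in inhibition remains open.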